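From a Fused Ring to a Single Thiazole

The compounds below may be only part of what the source reports. "The series", "measured", "known", "first", "only" and "open" are said of these compounds alone.

Three compounds share one core and differ only in the group carried on an amide-type nitrogen. Compound 1 `Cc1ccc2nc(NC(=O)CNC(=O)c3nn(-c4ccccc4)c(=O)c4ccccc34)sc2c1` gives 35 nM in an assay on L cells for inhibition of Protein-serine O-palmitoleoyltransferase porcupine (Mus musculus), read by reporter gene assay, with a stated time of 24 h; on this read-out lower numbers stand for an effect already at smaller amounts and higher numbers for an effect only at larger amounts of compound. Compound 3 `COc1ccc2nc(NC(=O)CNC(=O)c3nn(-c4ccccc4)c(=O)c4ccccc34)sc2c1` gives 210 nM in this assay, the higher of the two actual numbers, with the step of a 6.0-fold higher number from compound 1 to compound 3 (0.78 log units; beyond the scatter). Compound 2 `CCOC(=O)c1ccc2nc(NC(=O)CNC(=O)c3nn(-c4ccccc4)c(=O)c4ccccc34)sc2c1` reaches only the limit of > 25000 nM in this assay, so no number is known for it. the limit of > 25000 nM in this assay, at which 1 of the 3 values shown sits, marks where that limit sits. The step of an at least 710-fold higher number from compound 1 to compound 2 (2.85 log units; beyond the scatter) and the step of an at least 110-fold lower number from compound 2 to compound 3 (2.07 log units; beyond the scatter) show how widely the outcome moves with a single group on an aromatic carbon.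

Compound 4 `O=C(CNC(=O)c1nn(-c2ccccc2)c(=O)c2ccccc12)Nc1nccs1` is not yet measured. It differs from compound 3 by 1,3-thiazol-2-yl in place of 6-methoxy-1,3-benzothiazol-2-yl on an amide-type nitrogen. Every measured step keeps the six-membered aromatic ring of carbon only and changes just a group on it; none removes that ring, so none bears directly on this change. Since even small changes here moved the number a great deal, a large upward step is expected, though its size is uncertain. For compound 4 the expected step is a 14-fold higher number from compound 3 to compound 4 (1.15 log units; beyond the scatter). Compound 4 is therefore estimated at 3000 nM, within a range from 400 nM to 25000 nM.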

Compound 4, half-maximal effective concentration: > 25000 nM
Compound 4 gave a limit, no number (the forecaster's own chance of this, stated with the estimate: 30%); middle value at least 8.3-fold (0.92 log units) away from the limit.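

Taking away the six-membered aromatic ring of carbon only, rather than changing a group on it, gives an at least 110-fold higher number from compound 3 to compound 4 (2.07 log units; beyond the scatter), and the same replacement gives an at least 710-fold higher number from compound 1 to compound 4 (2.85 log units; beyond the scatter). The value of compound 4 is a limit of the assay and not a number, so it cannot be ranked against compound 2, which stands at the same limit: the limit of > 25000 nM in this assay, at which 2 of the 4 values shown sit. Among these compounds, a measurable number appears only with the 6-methyl and 6-methoxy forms of the 1,3-benzothiazol-2-yl group, and compound 2 shows that keeping the fused ring is not enough on its own.

Going by these compounds, whether the ring itself matters or only the groups it carries remains open. A 1,3-thiazol-2-yl bearing a methyl group, or a 1,3-benzothiazol-2-yl bearing no group at all, could help separate the two.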